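Swapping a phenyl for a hydroxybutyl chain: what to expect

The source may report more compounds than this note shows. Statements on the series, on what has been measured and on what is new or still open speak of the compounds shown alone.

Of the compounds shown here, three have been tested in an ADME assay on BEAS-2B cells (Homo sapiens) for cytotoxicity, read by MTT assay, with a stated time of 72 h; a lower number here means a stronger inhibitor of growth, a higher number a weaker inhibitor of growth. Compound 3 `CSc1nc(NCc2ccccc2)c2cccnc2n1` gives 61700 nM, and compound 2 `CSc1nc(NCc2ccccc2)c2ccccc2n1` gives 88200 nM; these two differ in their cores, a difference that is not broken down here. Compound 1 `CSc1nc(NCCCCCO)c2cccnc2n1` gives only a limit of the assay, > 100000 nM. From compound 3 to compound 1 the change is 4-hydroxybutyl in place of phenyl on a saturated chain carbon bound to a nitrogen on an aromatic ring, and it makes an at least 1.6-fold higher number from compound 3 to compound 1 (0.20 log units; that floor lies within the scatter), a floor set by the limit of > 100000 nM in this assay, at which 1 of the 3 values shown sits. Compound 4 `CSc1nc(NCCCCCO)c2ccccc2n1` has not yet been measured; it carries the same change, (4-hydroxybutyl in place of phenyl on a saturated chain carbon bound to a nitrogen on an aromatic ring), on the core of compound 2. Resting on the value of compound 2, 88200 nM, and on the measured step just described, the expected step is a 1.5-fold higher number from compound 2 to compound 4 (0.17 log units; within the scatter). Compound 4 is therefore estimated at 130000 nM, quite possibly reported only as a limit.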

Compound 4, concentration for total growth inhibition: 99400 nM
The estimate for compound 4 lay 1.3-fold (0.12 log units) above the measured number; measured number inside the range.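

On the core of compound 2, 4-hydroxybutyl in place of phenyl gives a 1.1-fold higher number from compound 2 to compound 4 (0.05 log units; within the scatter), so in this assay this swap shows no readable effect on that core. Set beside the earlier step, this does not show that the change carries over in the same way from one core to the other, nor that it behaves differently: the same change on two cores in this assay, an at least 1.6-fold higher number (0.20 log units; that floor lies within the scatter) from compound 3 to compound 1 and a 1.1-fold higher number (0.05 log units; within the scatter) from compound 2 to compound 4; the limit leaves it open whether they differ. The value of compound 1, > 100000 nM, is a limit and not a number: the limit of > 100000 nM in this assay, at which 1 of the 4 values shown sits.

From the compounds shown here alone, it remains open whether any replacement for phenyl at this place would move the number beyond the scatter on either core. A longer chain, an amine or a carboxylic acid in place of the 4-hydroxybutyl would be further cases to compare.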